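A few compounds are considered here, and "the series" means these few. Any claim that something is new, unique, unknown or untested is made for them only; others in the source may bear on it.

Measured so far:
- compound 1, `CCOC(=O)c1cnnn1CCOCC1=NC(C)=C(C(=O)OC)C(c2ccccc2Cl)/C1=C(\O)OCC`: 100 nM in a functional assay (aorta) with Rattus norvegicus as the target; on this read-out lower numbers stand for stronger inhibition and higher numbers for weaker inhibition
- compound 2, `CCO/C(O)=C1\C(COCCN2CC(=O)N(C)C2=O)=NC(C)=C(C(=O)OC)C1c1cccc(Cl)c1Cl`: 5.01 nM

Both compounds were tested in this assay. Compound 1 gives the higher of the two numbers; compound 2 sits well below it, and the gap between compound 1 and compound 2 lies beyond the usual scatter. The two compounds differ in more than one place, so the gap cannot be laid at the door of any single change.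

Compound 3, `CCO/C(O)=C1\C(COCCN2CC(=O)N=C2N)=NC(C)=C(C(=O)OC)C1c1ccccc1Cl`, has not been measured. Next to compound 1 it shows one change: a group of 7 heavy atoms (3 carbon, 3 nitrogen, 1 oxygen; one five-membered non-aromatic ring with 2 hetero atoms) in place of a group of 10 heavy atoms (5 carbon, 3 nitrogen, 2 oxygen; one five-membered aromatic ring with 3 hetero atoms), on a saturated chain carbon, two bonds along the chain from an oxygen on a saturated carbon. Among the compounds with values here, no measured pair shows this exact exchange, so the outcome rests on expectation alone.

Since the shared core and the rest of the side chain are kept, a modest step is expected from compound 1 to compound 3 in this assay, of about a 1.4-fold lower number from compound 1 to compound 3 (0.15 log units; within the scatter), towards a slightly lower number, but it may well stay within the scatter. Compound 3 is therefore expected to give roughly 70 nM, with a range from 15 nM to 350 nM.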

Compound 3, half-maximal inhibitory concentration: 20 nM
Compound 3: middle estimate off by 3.5-fold (0.54 log units), on the high side, and the stated range covers the measured number.
By their numbers in this assay, from the lowest: compound 2; then compound 3; then compound 1.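

At the saturated chain carbon, two bonds along the chain from an oxygen on a saturated carbon, the end group of the side chain clearly matters in this assay: replacing 5-(ethoxycarbonyl)-1H-1,2,3-triazol-1-yl with the smaller five-membered non-aromatic ring gives a 5.0-fold lower number from compound 1 to compound 3 (0.70 log units; beyond the scatter). Unlike the gap between the two earlier compounds, which differ in more than one place, this step traces to a single exchange and lies beyond the usual scatter. No measurement here explains why the number falls with this exchange, so the step stands as an observation only.

The exchange alters the ring type and also removes the ethoxycarbonyl group, and the compounds shown cannot separate these two parts, as none carries a 1H-1,2,3-triazol-1-yl group without the ethoxycarbonyl. On these data alone, it also remains open how far this position tolerates other end groups, such as a simple amine or a carboxylic acid on the same chain carbon.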